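Swapping the aryl group in an acrylate-type ester series

The source may hold more compounds than are shown below. What is called first, only, known or untested is meant among the compounds shown, and "the series" means these compounds.

Measured so far:
- Compound 1 `COc1ccc(C(=O)/C(=C/c2ccc(C(F)(F)F)cc2)CC(C)C)cc1`: > 100000 nM
- Compound 2 `C=C(C(=O)c1ccc(OC)cc1)C(OC(C)=O)c1ccc(Cl)cc1Cl`: 8300 nM
- Compound 3 `C=C(C(=O)c1ccc(OC)cc1)C(OC(=O)c1ccccc1)c1ccc(Cl)cc1Cl`: 26800 nM

In a functional assay on MCF7 cells (Homo sapiens) for inhibition, read by XTT assay, with a stated time of 48 h (on this read-out lower numbers stand for stronger inhibition and higher numbers for weaker inhibition), compound 1 reaches only a limit of the assay, > 100000 nM, so no number is known for it (the limit of > 100000 nM in this assay, at which 1 of the 3 values shown sits). Compound 2 gives 8300 nM in this assay, and compound 3 gives 26800 nM, the highest of the two numbers shown; the single measured step, a 3.2-fold higher number from compound 2 to compound 3 (0.51 log units; beyond the scatter), is modest. Compound 4 `C=C(C(=O)c1ccc(OC)cc1)C(OC(=O)c1ccccc1)c1c(F)c(F)c(F)c(F)c1F` is not yet measured. It differs from compound 3 by 2,3,4,5,6-pentafluorophenyl in place of 2,4-dichlorophenyl on a saturated chain carbon bound to a double-bonded chain carbon and an oxygen next to a carbonyl group. Among the compounds with values here, no measured step touches this aryl group, so nothing here points to a direction; the step of a 1.1-fold higher number from compound 3 to compound 4 (0.05 log units; within the scatter) is therefore expected to stay within the usual scatter. For compound 4 the estimate in this assay is 30000 nM, with a range from 8000 nM to 100000 nM.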

Compound 4, half-maximal inhibitory concentration: 45300 nM
For compound 4 the middle estimate is 1.5-fold (0.18 log units) below the measured one; the range from low to high includes it.
By their numbers in this assay, from the lowest: compound 2; then compounds 3 and 4 (each within the scatter of the next). At a limit, above all of these: compound 1.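

Within the data shown here, no earlier step touched this aryl group, and 2,3,4,5,6-pentafluorophenyl in place of 2,4-dichlorophenyl gives a 1.7-fold higher number from compound 3 to compound 4 (0.23 log units; within the scatter) in this series. On this evidence, the two halogen-bearing aryl groups cannot be told apart at this position. Nothing shown gives a reason for this result.

Going by these compounds, it remains open whether a plain phenyl, or a phenyl carrying an amine or a carboxylic acid, would read differently here. On these data alone, it is also open whether the same swap would hold with the methyl on the carbonyl carbon of compound 2.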